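Phenyl to 3-chlorophenyl from compound 2

The source may report more compounds than this note shows. Statements on the series, on what has been measured and on what is new or still open speak of the compounds shown alone.

In a functional assay on HCT-116 cells (Homo sapiens) for antiproliferative activity, read by CCK-8 assay, with a stated time of 72 h (on this read-out lower numbers stand for stronger inhibition and higher numbers for weaker inhibition), compound 2 (`Nc1ccccc1NC(=O)c1ccc(Cn2cnc3c(Nc4ccccc4)nc(Cl)nc32)cc1`) gives 1070 nM. Two other compounds sit within the scatter of that number: compound 3 (`Nc1ccccc1NC(=O)c1ccc(COCNc2nc(Nc3ccccc3)c3ncn(C4CCCC4)c3n2)cc1`) gives 960 nM and compound 1 (`CCC(C)n1cnc2c(NCc3ccc(C(=O)Nc4ccccc4N)cc3)nc(Cl)nc21`) gives 720 nM. These three structures differ from one another in more than one place, and their values do not separate, so the set gives no ranking.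

The next compound is compound 4 (`Nc1ccccc1NC(=O)c1ccc(Cn2cnc3c(Nc4cccc(Cl)c4)nc(Cl)nc32)cc1`), not yet measured in this assay. It keeps the structure of compound 2 except for one change, phenyl to 3-chlorophenyl: chloro in place of hydrogen on an aromatic carbon. This is chloro in place of hydrogen on an aromatic carbon of the anilino group.

Among the measured compounds shown here, no two measured compounds differ in one place only, so the data hold no direct precedent for the size or direction of this step. The expectation therefore starts from compound 2 at 1070 nM, and no step beyond the scatter is expected in either direction. The estimated change is small, a 1.3-fold lower number from compound 2 to compound 4 (0.10 log units; within the scatter), and only tentatively towards a lower number. For compound 4 the expected value is 850 nM, with an estimated range of 300 nM to 2200 nM.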

Compound 4, half-maximal inhibitory concentration: 2340 nM
For compound 4 the middle estimate is 2.8-fold (0.44 log units) below the measured one, outside the stated range (above it).
By their numbers in this assay, from the lowest: compounds 1, 3 and 2 (each within the scatter of the next); then compound 4.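

In this assay the anilino group gives the series its first single-place step: phenyl to 3-chlorophenyl, chloro in place of hydrogen on an aromatic carbon, brings a 2.2-fold higher number from compound 2 to compound 4 (0.34 log units; beyond the scatter) and stays modest but lies beyond the scatter. This place on the anilino group therefore does not tolerate every change without consequence, and one chlorine atom there is enough to move the number towards weaker inhibition, something the three earlier compounds could not show, as they differ from one another in more than one place and their values stay within the scatter. Nothing measured here bears on the reason for this step.

From the compounds shown here alone, it remains open whether the step belongs to chloro alone, or whether a fluoro, a methoxy or an amine on the same aromatic carbon would move the number in the same direction and by a similar size. Going by these compounds, it is equally open whether the same chloro change on the anilino group of compound 3, whose remaining structure differs from that of compound 2, would give a comparable step.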